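The source may report more compounds than this note shows. Statements on the series, on what has been measured and on what is new or still open speak of the compounds shown alone.

Compound 1 `COc1ccc(N(C)c2nc(C)nc3ccccc23)cc1C(=O)OCC[Se]C#N` gives 2390 nM
Compound 2 `COc1ccc(N(C)c2nc(C)nc3ccccc23)cc1OCCCCCC[Se]C#N` gives 1540 nM
Compound 3 `COc1ccc(N(C)c2nc(C)nc3ccccc23)cc1[Se]C` gives 11 nM

In a functional assay on RKO cells (Homo sapiens) for inhibition, read by MTT assay, with a stated time of 48 h (on this read-out higher numbers stand for weaker inhibition and lower numbers for stronger inhibition), compound 3 has the lowest number of the three, and its gaps to the other two lie beyond the scatter. Compound 4 `COc1ccc(N(C)c2nc(C)nc3ccccc23)cc1C(=O)OCCCC[Se]C#N` alters compound 3 at one place: a group of 10 heavy atoms (6 carbon, 1 nitrogen, 2 oxygen, 1 selenium; no ring) in place of a group of 2 heavy atoms (1 carbon, 1 selenium; no ring), on an aromatic carbon. Compound 1 and compound 2 also carry large groups on that carbon, so the measured steps to compound 3 bear directly on this change. There is a 220-fold lower number from compound 1 to compound 3 (2.34 log units; beyond the scatter), and there is a 140-fold lower number from compound 2 to compound 3 (2.15 log units; beyond the scatter). Both are large, and here the direction reverses. Between the two large groups there is only a 1.6-fold lower number from compound 1 to compound 2 (0.19 log units; within the scatter). A large rise in this assay is therefore expected, namely a 180-fold higher number from compound 3 to compound 4 (2.26 log units; beyond the scatter). Compound 4 is estimated at 2000 nM, with an expected range of 700 nM to 5500 nM.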

Compound 4, half-maximal inhibitory concentration: 1020 nM
Beside the measured number, compound 4's estimate is 2.0-fold (0.29 log units) above it, and the stated range covers the measured number.
By their numbers in this assay, from the lowest: compound 3; then compounds 4, 2 and 1 (each within the scatter of the next, the first and the last beyond it).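

Replacing the small selenium group with the long ester chain gives a 93-fold higher number from compound 3 to compound 4 (1.97 log units; beyond the scatter) on this aromatic carbon, so a third large group sits far from compound 3. Among the large groups, the longer saturated chain gives a 2.3-fold lower number from compound 1 to compound 4 (0.37 log units; beyond the scatter) and a modest gain at most, while swapping the chain of compound 2 for that of compound 4 gives a 1.5-fold lower number from compound 2 to compound 4 (0.18 log units; within the scatter) and no real separation. No evidence here explains these steps. Still open, on these data alone, is whether a selenium group of middling size, such as ethylselenyl, keeps the low number of compound 3. Also open, as far as these compounds go, is how a short chain ending in an amine or a carboxylic acid would behave at this position.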